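Isatin thiosemicarbazones on MCF7 cells: a nitrophenyl variant

This account rests on a few compounds, and the source may have more. Where it says the series, first, only, none or still open, it means among the compounds named here.

Measured compounds:
- compound 1, `O=C1Nc2ccc(F)cc2/C1=N/NC(=S)N1CCN(c2ccccc2)CC1`: 24300 nM
- compound 2, `Cc1ccccc1N1CCN(C(=S)N/N=C2\C(=O)Nc3ccc(Cl)cc32)CC1`: 10900 nM

Within the data shown here, in a functional assay on MCF7 cells (Homo sapiens) for inhibition, read by MTT assay, with a stated time of 72 h (on this read-out higher numbers stand for weaker inhibition and lower numbers for stronger inhibition), compound 2 gives 10900 nM, the lower of the two numbers known so far; compound 1 gives 24300 nM, a gap that lies beyond the usual scatter. The two compounds differ in more than one place, so no single change can be credited with this gap.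

Compound 3, `O=C1Nc2ccc(Cl)cc2/C1=N/NC(=S)N1CCN(c2ccc([N+](=O)[O-])cc2)CC1`, is not yet measured. It keeps the core of compound 2 and differs in one place: 4-nitrophenyl in place of 2-methylphenyl on an amine nitrogen in a ring. Among the measured compounds shown here, no step between measured compounds isolates a change of this kind, so there is no direct precedent. The substituent on the ring nitrogen has so far moved numbers only modestly, and a step of no more than moderate size in either direction, possibly none beyond the scatter, is expected in this assay.

For compound 3 the expected value in this assay is 9000 nM, with a range from 3000 nM to 30000 nM, corresponding to an estimated step of a 1.2-fold lower number from compound 2 to compound 3 (0.08 log units; within the scatter).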

Compound 3, half-maximal inhibitory concentration: 20900 nM
For compound 3 the middle estimate is 2.3-fold (0.37 log units) below the measured one; measured number inside the range.
By their numbers in this assay, from the lowest: compounds 2, 3 and 1 (each within the scatter of the next, the first and the last beyond it).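

In this assay, among these compounds, 4-nitrophenyl in place of 2-methylphenyl on the amine nitrogen in the ring gives a 1.9-fold higher number from compound 2 to compound 3 (0.28 log units; within the scatter), the first step that isolates a change at this place. Compound 2 and compound 3 cannot be told apart on this read-out, even though 4-nitrophenyl carries hydrogen-bond acceptors and 2-methylphenyl carries none. No measurement of any property of these groups bears on this result, and it offers no explanation for the two numbers lying within the scatter.

From the compounds shown here alone, it remains open whether a different kind of group on this nitrogen, such as a benzyl group or a longer alkyl chain, or an amine or a carboxylic acid on the phenyl ring, would give a step beyond the scatter. The separate contribution of chloro and fluoro on the shared core also remains unresolved.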